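Methoxy in Place of Hydrogen: Expected Cytotoxicity on Liver Cells

A few compounds are considered here, and "the series" means these few. Any claim that something is new, unique, unknown or untested is made for them only; others in the source may bear on it.

Compound 1, `Cn1nc(-c2nnc(-c3ccccc3)o2)c2ccccc21`, gives 84600 nM in an ADME assay on L02 cells (Homo sapiens) for cytotoxicity, read by MTT assay, with a stated time of 72 h; a lower number here means a stronger inhibitor, a higher number a weaker inhibitor.
Compound 2, `Cn1nc(-c2nnc(-c3ccccc3Cl)o2)c2ccccc21`, reaches only a limit of the assay, > 100000 nM.

Compound 1 holds the only number shown; the other value is a limit. Compound 3, `COc1ccc(-c2nnc(-c3nn(C)c4ccccc34)o2)cc1`, arises from compound 1 by the change (methoxy in place of hydrogen on an aromatic carbon). Going by the values given here, the one measured step that bears on it is an at least 1.1-fold higher number from compound 1 to compound 2 (0.07 log units; that floor lies within the scatter), where a chloro enters on the same ring; it sits at the limit of > 100000 nM in this assay, at which 1 of the 2 values shown sits. That step shows no movement beyond the scatter, so the methoxy is expected to leave the value near that of compound 1, with no step beyond the scatter in either direction. Compound 3 is therefore estimated at 90000 nM, within 40000 nM to 200000 nM. The estimated step of a 1.1-fold higher number from compound 1 to compound 3 (0.03 log units; within the scatter) is expected to stay within the scatter, and the result may well come back as a limit, as it did for compound 2.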

Compound 3, half-maximal inhibitory concentration: > 100000 nM
Compound 3: only a limit was reported (the forecaster's own chance of this, stated with the estimate: 50%); middle value at least 1.1-fold (0.04 log units) away from the limit.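

In this assay, methoxy in place of hydrogen on an aromatic carbon, para to a large group, gives an at least 1.1-fold higher number from compound 1 to compound 3 (0.07 log units; that floor lies within the scatter). Compound 3 gives > 100000 nM, and that is a limit, not a measured number. This adds a second group on the same carbon-only ring that ends at a limit, as the chloro of compound 2 did, and neither step shows a number that falls: the limit of > 100000 nM in this assay, at which 2 of the 3 values shown sit.

Going by these compounds, how far past this limit compound 2 and compound 3 truly lie stays unknown, so the full size of both steps stays unknown too. On these data alone, whether an amine or a carboxylic acid at the same place would bring the value down to a measurable number, or leave it at the limit, also remains open.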